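Propyl to 5-methyl-1,2-oxazol-3-yl at the amide carbonyl

A few compounds are considered here, and "the series" means these few. Any claim that something is new, unique, unknown or untested is made for them only; others in the source may bear on it.

Compound 1 `COc1ccc(OCC(=O)Nc2cccc(NC(=O)c3ccc(N(C)C)cc3)c2)cc1OC` in an assay on isolated protein for inhibition of Rho-associated protein kinase 1 (Homo sapiens), read by scintillation counting, radiometric assay and 33P incorporation, with a stated time of 40 min, in the presence of a further agent that is not named here (on this read-out lower numbers stand for stronger inhibition and higher numbers for weaker inhibition), reaches only a limit, > 10000 nM. Among the compounds with values here, compound 2 `CCCC(=O)Nc1cccc(NC(=O)COc2ccc3c(=O)ccoc3c2)c1` gives 1430 nM in this assay and thus holds the only number in the set. The remaining value, that of compound 1, is a limit, (the limit of > 10000 nM in this assay, at which 1 of the 2 values shown sits). Compound 3 `Cc1cc(C(=O)Nc2cccc(NC(=O)COc3ccc4c(=O)ccoc4c3)c2)no1` is not yet measured; against compound 2 it carries 5-methyl-1,2-oxazol-3-yl in place of propyl on a carbonyl carbon. Within the data shown here, no step between measured compounds covers a change of this kind, so the data give no size for it. The step of a 1.3-fold lower number from compound 2 to compound 3 (0.11 log units; within the scatter) is expected to stay within the scatter. Compound 3 is therefore estimated at 1100 nM, within a range from 300 nM to 4500 nM.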

Compound 3, half-maximal inhibitory concentration: 68 nM
Beside the measured number, compound 3's estimate is 16-fold (1.21 log units) above it, and the stated range ends above it.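

This place on the carbonyl carbon responds strongly to the group it carries: in this assay, 5-methyl-1,2-oxazol-3-yl in place of propyl gives a 21-fold lower number from compound 2 to compound 3 (1.32 log units; beyond the scatter). Within the data shown here, this is the first size available for a change at this place, and it comes with the rest of the structure held constant. Nothing measured in the set bears on why the step is this large.

From the compounds shown here alone, whether the ring, its methyl group or its hydrogen-bond acceptors carry the step stays open. A phenyl ring, an unsubstituted 1,2-oxazol-3-yl group or a longer chain at this place would help to separate them.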